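Furan-3-yl in place of 1H-pyrazol-4-yl: expected step

A few compounds are considered here, and "the series" means these few. Any claim that something is new, unique, unknown or untested is made for them only; others in the source may bear on it.

Measured so far in a functional assay on PC-3 cells (Homo sapiens) for antiproliferative activity, read by CCK-8 assay, with a stated time of 6 days (on this read-out lower numbers stand for stronger inhibition and higher numbers for weaker inhibition), across the series:
- compound 1 `CCN(c1ccc(C#N)c(Cl)c1)c1cc(-c2ccncc2)ccc1C` gives 3580 nM here
- compound 2 `CCN(c1ccc(C#N)c(Cl)c1)c1cc(-c2cn[nH]c2)ccc1C` gives 15300 nM here

Compound 2 holds the higher of the two numbers, so it is the weaker inhibitor of the pair. Going by the values given here, compound 3 `CCN(c1ccc(C#N)c(Cl)c1)c1cc(-c2ccoc2)ccc1C` has not been measured and carries furan-3-yl in place of 1H-pyrazol-4-yl on an aromatic carbon as its only change. Among the compounds with values here, one measured step bears on this, a 4.3-fold higher number from compound 1 to compound 2 (0.63 log units; beyond the scatter) on going from pyridin-4-yl to 1H-pyrazol-4-yl, modest and beyond the scatter. Within the data shown here, no furan-bearing compound has been measured, so that single step sets the scale. A modest step toward a lower number is therefore expected in this assay for this change. The estimate amounts to a 2.2-fold lower number from compound 2 to compound 3 (0.34 log units; beyond the scatter) on this read-out. The expected value for compound 3 is 7000 nM within an estimated range of 2500 nM to 20000 nM overall.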

Compound 3, half-maximal inhibitory concentration: > 30000 nM
Compound 3 was reported as a limit; the forecaster's own chance of this, stated with the estimate: 5%; middle value at least 4.2-fold (0.63 log units) from the limit.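

In this assay, compound 3 is read only as a limit, not as a number: the limit of > 30000 nM in this assay, at which 1 of the 3 values shown sits.

Replacing pyridin-4-yl with furan-3-yl at this position gives an at least 8.3-fold higher number from compound 1 to compound 3 (0.92 log units; beyond the scatter), so compound 1 is the strongest of the three, with its steps to compound 2 and compound 3 both beyond the scatter. Replacing 1H-pyrazol-4-yl with furan-3-yl gives an at least 1.9-fold higher number from compound 2 to compound 3 (0.29 log units; that floor lies within the scatter), so this floor does not firmly separate these two five-membered rings, although the entering ring has 0 hydrogen-bond donors and the leaving ring has 1.

On these data alone, the true value of compound 3 and the role of that donor remain open. Also open, as far as these compounds go, is whether pyridin-3-yl, or a phenyl ring carrying an amine, would give a lower number than compound 1.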